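Adding a Second Bromo Group to Compound 2

The compounds below may be only part of what the source reports. "The series", "measured", "known", "first", "only" and "open" are said of these compounds alone.

Values in a physicochemical assay for metabolic stability; a lower number here means that the compound disappears faster, a higher number that the compound lasts longer:
Compound 1 `Cc1cccc(C(=O)n2ncc3c2CCCC3=O)c1`: 1.64 h
Compound 2 `O=C1c2cn(C(=O)C3CC3)nc2CCC1Br`: 1.91 h

Compound 2, at 1.91 h, lies within the usual scatter of compound 1, at 1.64 h, so these two numbers cannot be told apart. Compound 3 `O=C(C1CC1)n1cc2c(n1)CCC(Br)(Br)C2=O` has one structural change from compound 2: bromo in place of hydrogen on a saturated ring carbon, with bromo in place of hydrogen on a saturated ring carbon. For the measured compounds named here, no measured pair shows this change, so the data suggest no direction, and no shift beyond the scatter is expected. The expected change is a 1.1-fold lower number from compound 2 to compound 3 (0.05 log units; within the scatter). For compound 3, the estimate is 1.7 h, with an expected range of 0.8 h to 3.4 h.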

Compound 3, half-life: 0.645 h
Compound 3: middle estimate off by 2.6-fold (0.42 log units), on the high side; measured number below the stated range.
By their numbers in this assay, from the lowest: compound 3; then compounds 1 and 2 (each within the scatter of the next).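

In this assay, putting a second bromo in place of hydrogen on this saturated ring carbon gives a 3.0-fold lower number from compound 2 to compound 3 (0.47 log units; beyond the scatter), so this position can change the half-life. Compound 1 and compound 2 differ in more than one place, so they could not show this. Nothing measured here gives a reason for the drop. From the compounds shown here alone, whether it is specific to bromo remains open, as does whether any second group on this carbon would do the same. A fluoro or chloro group at this position would help separate these two possibilities.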